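A few compounds are considered here, and "the series" means these few. Any claim that something is new, unique, unknown or untested is made for them only; others in the source may bear on it.

Measured compounds:
compound 1 `COc1cc(N)c(Cl)cc1C(=O)CCC1CCN(CCNS(=O)(=O)c2ccc(N)cc2)CC1` — 1.97 nM
compound 2 `COc1ccc(S(=O)(=O)NCCN2CCC(CCC(=O)c3cc(Cl)c(N)cc3OC)CC2)cc1` — 12.3 nM
compound 3 `COc1ccc(S(=O)(=O)NCCN2CCC(CCC(=O)c3cc(Cl)c(N)cc3OC)CC2)c(OC)c1` — 18.7 nM

In an assay on brain for displacement of a labelled ligand from 5-hydroxytryptamine receptor 4 (Cavia porcellus), with a stated time of 30 min, in the presence of a further agent that is not named here (a higher number here means a weaker inhibitor, a lower number a stronger inhibitor), compound 3 gives the highest number of the three. Its nearest neighbour is compound 2, with a 1.5-fold higher number from compound 2 to compound 3 (0.18 log units; within the scatter), and its furthest is compound 1, with a 9.5-fold higher number from compound 1 to compound 3 (0.98 log units; beyond the scatter). Compound 4 `COc1cc(N)c(Cl)cc1C(=O)CCC1CCN(CCNS(=O)(=O)c2ccc(N)c(Br)c2)CC1` differs from compound 3 in one place: 4-amino-3-bromophenyl in place of 2,4-dimethoxyphenyl on a sulfonyl sulfur. The change largely undoes the step of a 9.5-fold higher number from compound 1 to compound 3 (0.98 log units; beyond the scatter), in which 2,4-dimethoxyphenyl had replaced 4-aminophenyl on the sulfonyl sulfur; the aminophenyl now returns, carrying a bromine in addition. Among the measured compounds shown here, no measured pair shows what that added bromine does on its own, so this part of the change has no support in the numbers. A step to a lower number is therefore expected, of roughly the size seen between compound 1 and compound 3 but reversed, with the uncertainty widened for the bromine. The expected step from compound 3 to compound 4 is a 6.2-fold lower number from compound 3 to compound 4 (0.79 log units; beyond the scatter). Compound 4 is estimated at 3 nM, within 1 nM to 10 nM.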

Compound 4, inhibition constant: 5.3 nM
The estimate for compound 4 lay 1.8-fold (0.25 log units) below the measured number, within the range that was stated.
By their numbers in this assay, from the lowest: compound 1; then compound 4; then compounds 2 and 3 (each within the scatter of the next).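

In this assay, the bromo on the 4-aminophenyl ring can now be read alone, and adding it raises the number, with a 2.7-fold higher number from compound 1 to compound 4 (0.43 log units; beyond the scatter). Even with that bromo, the amino-bearing ring keeps an advantage over both methoxy-bearing rings on the sulfonyl sulfur, with a 2.3-fold lower number from compound 2 to compound 4 (0.37 log units; beyond the scatter) and a 3.5-fold lower number from compound 3 to compound 4 (0.55 log units; beyond the scatter), so 4-amino-3-bromophenyl ranks behind 4-aminophenyl but ahead of 4-methoxyphenyl and 2,4-dimethoxyphenyl, which lie within the scatter of each other. No supporting data bear on why these steps arise.

On these data alone, whether chloro or fluoro in place of the bromo would give a smaller step than the one seen with bromo remains open. Also open, as far as these compounds go, is whether the amino is still needed once a halogen is present, which a hydroxyl in its place could test.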